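A few compounds are considered here, and "the series" means these few. Any claim that something is new, unique, unknown or untested is made for them only; others in the source may bear on it.

Compound 1 `COc1cc(-c2nn(-c3cccc(NC(=O)Nc4ccc(Cl)c(Cl)c4)c3)cc2-c2ccncc2)ccc1Cl` gives > 50000 nM in a functional assay on A549 cells (Homo sapiens) for inhibition, read by sulforhodamine B assay, with a stated time of 48 h; on this read-out lower numbers stand for higher toxicity in this test and higher numbers for lower toxicity in this test; this is a limit of the test, not a number.
Compound 2 `O=C(Nc1cccc(-n2cc(-c3ccncc3)c(-c3ccc(Cl)c(O)c3)n2)c1)Nc1ccc(Cl)c(Cl)c1` gives > 32500 nM in this assay, again a limit.
Compound 3 `O=C(Nc1cccc(-n2cc(-c3ccncc3)c(-c3ccc(Cl)c(O)c3)n2)c1)Nc1cc(C(F)(F)F)cc(C(F)(F)F)c1` gives 11400 nM in this assay.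

Within the data shown here, compound 1 therefore stands only at a limit, the one named in the limit of > 50000 nM in this assay, at which 1 of the 3 values shown sits, and of the three values only that of compound 3 is a number. Among the measured compounds shown here, the one step between measured compounds, a step that the two limits leave unreadable from compound 1 to compound 2, cannot be read because the limit of > 32500 nM in this assay, at which 1 of the 3 values shown sits, and the limit of > 50000 nM in this assay, at which 1 of the 3 values shown sits, both mark limits. For the measured compounds named here, compound 3 gives a number in this assay while compound 2 sits at a limit; no step between the two is given, so only their values are known.

Compound 4 `COc1cc(-c2nn(-c3cccc(NC(=O)c4ccccc4)c3)cc2-c2ccncc2)ccc1Cl` differs from compound 1 by phenyl in place of (3,4-dichlorophenyl)amino on a carbonyl carbon, so the urea of compound 1 becomes a benzamide. Going by the values given here, no measured step touches this part of the molecule, so nothing measured bears directly on the change. The expectation rests on compound 1 alone, whose > 50000 nM is a limit. Compound 4 is expected to give about 60000 nM in this assay, with a range from 20000 nM to 200000 nM. The step that the limit leaves unreadable from compound 1 to compound 4 is thus estimated to lie within the scatter, and it is expected that the test will most likely again report only a limit for compound 4.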

Compound 4, concentration lethal to 50% of the cells: > 100000 nM
Compound 4: no number, only a limit; the forecaster's own chance of this, stated with the estimate: 70%; middle value at least 1.6-fold (0.22 log units) from the limit.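

Compound 1 and compound 4 both give only limits in this assay, not numbers, and the step between them cannot be read. The compounds shown leave open whether phenyl in place of (3,4-dichlorophenyl)amino on the carbonyl carbon changes the toxicity in this test at all, and in which direction.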